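This account rests on a few compounds, and the source may have more. Where it says the series, first, only, none or still open, it means among the compounds named here.

Compound 1 `C[C@@H]1CCCN1c1c(C#N)c2c(N)nc(Nc3cn(C)nc3Cl)nc2n1C` and compound 3 `Cc1c(Nc2nc(N)c3c(C#N)c(N4CCC[C@H]4C)n(C)c3n2)cnn1C` share one core; the two differ only in the group attached to a nitrogen on an aromatic ring. Among the compounds with values here, in an ADME assay on microsomes from liver (Homo sapiens) for pharmacokinetics (on this read-out higher numbers stand for fast clearance and lower numbers for slow clearance), compound 1 gives 183 mL/min/kg, a fast-clearance reading; it is the only plain number this compound carries here, a further entry giving no single figure. Compound 2 `Cc1nn(C2CCOC2)cc1Nc1nc(N)c2c(C#N)c(N3CCC[C@H]3C)n(C)c2n1`, a relative with a different ring on that same nitrogen, has been measured more than once in this assay, and there compound 2 gives 76.7 mL/min/kg; 200 mL/min/kg (2 entries); that spread, seen in the several entries of compound 2 in this assay, 76.7 mL/min/kg; 200 mL/min/kg (2 entries), shows how far repeats of one compound can lie apart in this assay. The change from compound 1 to compound 3 is 1,5-dimethyl-1H-pyrazol-4-yl in place of 3-chloro-1-methyl-1H-pyrazol-4-yl on a nitrogen on an aromatic ring. Within the data shown here, no measured pair shows a step of this kind, so the expectation for this assay rests on compound 1 alone. Compound 3 is expected to stay close to compound 1, with the step from compound 1 to compound 3 estimated as a 1.0-fold higher number from compound 1 to compound 3 (0.02 log units; within the scatter), a change within the scatter and in no fixed direction. The clearance of compound 3 is therefore estimated at 190 mL/min/kg, with a range from 95 mL/min/kg to 380 mL/min/kg.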

Compound 3, clearance: 41.7 mL/min/kg
Beside the measured number, compound 3's estimate is 4.6-fold (0.66 log units) above it; measured number below the stated range.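

Within the data shown here, the group on a nitrogen on an aromatic ring clearly has a say in human liver microsome clearance, which the earlier compounds could not show because no measured pair isolated a change there. In this assay, replacing 3-chloro-1-methyl-1H-pyrazol-4-yl with 1,5-dimethyl-1H-pyrazol-4-yl gives a 4.4-fold lower number from compound 1 to compound 3 (0.64 log units; beyond the scatter), even though both groups have the same number of heavy atoms, hydrogen-bond donors and acceptors, and neither carries a net charge. This is a single pair, however, and the step is modest and rests on one reading for each compound, while repeats of one compound in this assay can lie far apart: the several entries of compound 2 in this assay, 76.7 mL/min/kg; 200 mL/min/kg (2 entries)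

The step removes the chloro group and adds a second methyl group at once, so the compounds shown leave open which of the two goes with the lower number. Also open, going by these compounds, is how clearance would respond to a methoxy group or an amine on the same pyrazole ring, and whether the step would hold up on repeated measurement.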